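The compounds below may be only part of what the source reports. "The series", "measured", "known", "first", "only" and "open" are said of these compounds alone.

Compound 1 `CCCc1ccc(C#CC#Cc2cn([C@H]3C[C@H](O)[C@@H](CO)O3)c(=O)[nH]c2=O)cc1` is examined in an ADME assay on HEL cells (Homo sapiens), read by cell counting, with a stated time of 3 days (a lower number here means that less compound is tolerated, a higher number that more compound is tolerated), where compound 1 gives 52000 nM. Within the data shown here, of the two numbers known, this is the highest; the nearest is compound 2 `CC(O)CC#CC#Cc1cn([C@H]2C[C@H](O)[C@@H](CO)O2)c(=O)[nH]c1=O`, which in this assay gives 9500 nM, a step of a 5.5-fold lower number from compound 1 to compound 2 (0.74 log units; beyond the scatter). Compound 3 `O=c1[nH]c(=O)n([C@H]2C[C@H](O)[C@@H](CO)O2)cc1C#CC#CCO` reaches only a limit in this assay, > 100000 nM. This is the limit of > 100000 nM in this assay, at which 1 of the 3 values shown sits, so the step of an at least 1.9-fold higher number from compound 1 to compound 3 (0.28 log units; that floor lies within the scatter) is a floor. The pair from compound 2 to compound 3 shows an at least 10-fold higher number from compound 2 to compound 3 (1.02 log units; beyond the scatter).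

Compound 4 `O=c1[nH]c(=O)n([C@H]2C[C@H](O)[C@@H](CO)O2)cc1C#CC#CC1CC1` differs from compound 1 by cyclopropyl in place of 4-propylphenyl on a triple-bonded carbon. The two steps from compound 1 that alter the same triple-bonded carbon pull in opposite directions, one modest and lower with 2-hydroxypropyl, one a floor within the scatter with hydroxymethyl. Cyclopropyl shares neither of those groups, so no step beyond the scatter is expected in this assay. Compound 4 is therefore estimated at 40000 nM, between 12000 nM and 100000 nM, an expected step of a 1.3-fold lower number from compound 1 to compound 4 (0.11 log units; within the scatter).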

Compound 4, half-maximal cytotoxic concentration: > 100000 nM
Compound 4 ended at the assay's limit; the forecaster's own chance of this, stated with the estimate: 25%; at least 2.5-fold (0.39 log units) between middle value and limit.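

In this assay compound 4 joins compound 3 at a limit, which is not a number: the limit of > 100000 nM in this assay, at which 2 of the 4 values shown sit. On this triple-bonded carbon, the cyclopropyl change shows an at least 1.9-fold higher number from compound 1 to compound 4 (0.28 log units; that floor lies within the scatter), so it does not separate cyclopropyl from 4-propylphenyl, but it also shows an at least 10-fold higher number from compound 2 to compound 4 (1.02 log units; beyond the scatter). Compound 2 now has the lowest number of the four, with its steps to all three others beyond the scatter, and cyclopropyl reaches the limit without the hydroxy carried by compound 3, although the step between compound 3 and compound 4 cannot be read.

Still open, as far as these compounds go, is whether an amine or a longer unbranched carbon chain on this carbon would stay at the limit or fall towards compound 2. From the compounds shown here alone, how compound 3 and compound 4 rank against each other also remains open.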